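The source may hold more compounds than are shown below. What is called first, only, known or untested is meant among the compounds shown, and "the series" means these compounds.

Three compounds on one shared core have been taken through an ADME assay on CEMx174 cells (Homo sapiens) for cytotoxicity (a lower number here means that less compound is tolerated, a higher number that more compound is tolerated), so far, and none has yet given a plain number. Compound 1 (`CC(C)C1=C(C(=O)OCC2CCCCC2)C(c2cccc(O)c2)NC(=O)N1`) has the entry "not determined" (no result reported) and so offers no result. Compound 2 (`CC1=C(C(=O)OCC2CCCCC2)C(c2ccccc2O)NC(=O)N1`) has > 10000 nM as its entry, which is a limit of this assay and not a number. Compound 3 (`CCC1=C(C(=O)OCC2CCCCC2)C(c2cccc(N)c2)NC(=O)N1`) has > 10000 nM as its entry, again a limit and not a number. Compound 3 thus stands with the rest of the series: the data show the limit of > 10000 nM in this assay, at which 2 of the 3 values shown sit, and nothing sharper.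

Compound 4 (`CCC1=C(C(=O)OCC2CCCCC2)C(c2ccc(C#N)cc2)NC(=O)N1`) carries 4-cyanophenyl in place of 3-aminophenyl on a saturated ring carbon and is otherwise the same as compound 3. Among the measured compounds shown here, no pair of measured compounds gives the size of such a change, so the expectation rests only on compound 3 with its limit of > 10000 nM in this series. The estimated change a step that the limit leaves unreadable from compound 3 to compound 4 is expected to stay within the usual scatter, with neither direction favoured. For compound 4 the estimated half-maximal cytotoxic concentration is 15000 nM with an expected range from 5000 nM to 50000 nM and the assay may well report only a limit again.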

Compound 4, half-maximal cytotoxic concentration: > 10000 nM
Compound 4 gave a limit, no number; the forecaster's own chance of this, stated with the estimate: 75%; the middle value does not contradict the limit.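

Compound 4 gives > 10000 nM in this assay, which is a limit and not a number. Among the compounds shown here, as compound 3 also sits at a limit, no step between compound 3 and compound 4 can be read. The compounds shown leave open the actual half-maximal cytotoxic concentration of each, and whether 4-cyanophenyl and 3-aminophenyl differ at all in this assay.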